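The compounds below may be only part of what the source reports. "The series", "measured", "known", "first", "only" and "open" are said of these compounds alone.

Values in a functional assay on RS4-11 cells (Homo sapiens) for inhibition, read by CCK-8 assay, with a stated time of 48 h; on this read-out lower numbers stand for stronger inhibition and higher numbers for weaker inhibition:
- compound 1 `COc1ccc(Oc2ccccc2-c2ccsc2S(=O)(=O)N2CCN(C(=O)Nc3cccc([N+](=O)[O-])c3)CC2)cc1OC`: > 50000 nM (a limit)
- compound 2 `O=C(Nc1ccc(F)cc1)N1CCN(S(=O)(=O)c2sccc2-c2ccccc2Oc2ccc(O)c(O)c2)CC1`: 6800 nM
- compound 3 `COc1ccc(Oc2ccccc2-c2ccsc2S(=O)(=O)N2CCN(C(=S)Nc3ccc(Cl)cc3)CC2)cc1OC`: > 50000 nM (a limit)
- compound 4 `COc1ccc(Oc2ccccc2-c2ccsc2S(=O)(=O)N2CCN(C(=O)Nc3ccc(F)cc3)CC2)cc1OC`: not yet measured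

Compound 3 has no number of its own, only the limit > 50000 nM. Compound 1 likewise gives only a limit, > 50000 nM. Both therefore sit at the limit of > 50000 nM in this assay, at which 2 of the 3 values shown sit. Within the data shown here, the one actual number in the set belongs to compound 2, at 6800 nM.

The change under consideration is a group of 10 heavy atoms (7 carbon, 1 nitrogen, 1 oxygen, 1 fluorine; one six-membered aromatic ring of carbon only) in place of a group of 10 heavy atoms (7 carbon, 1 nitrogen, 1 sulfur, 1 chlorine; one six-membered aromatic ring of carbon only), on an amine nitrogen in a ring. Among the measured compounds shown here, the only measured step at this ring nitrogen is a step that the two limits leave unreadable from compound 1 to compound 3, so it offers no size to carry over. The (4-fluorophenyl)carbamoyl that enters in compound 4 is also carried by compound 2, which gives 6800 nM. However, compound 2 differs from compound 4 elsewhere on the core, and no measured step connects the two. Compound 4 keeps the core of compound 3, so a result in this assay at the same limit is the likeliest outcome, with a number close to it also possible. The expected change is an at least 1.1-fold lower number from compound 3 to compound 4 (0.04 log units; that floor lies within the scatter). For compound 4 the estimated value is 45000 nM, with an expected range from 18000 nM to 100000 nM.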

Compound 4, half-maximal inhibitory concentration: 14900 nM
The estimate for compound 4 lay 3.0-fold (0.48 log units) above the measured number, outside the stated range (below it).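

In this assay, among these compounds, compound 4 is the only compound with 3,4-dimethoxyphenyl that gives a number rather than a limit, which shows that the group on the amine nitrogen in a ring can shift the read-out on this core: the (4-fluorophenyl)carbamoyl change gives an at least 3.3-fold lower number from compound 3 to compound 4 (0.52 log units; beyond the scatter), and 4-fluorophenyl in place of 3-nitrophenyl on the amide-type nitrogen gives an at least 3.3-fold lower number from compound 1 to compound 4 (0.52 log units; beyond the scatter). Both sizes are only floors, and the step from compound 1 to compound 3 cannot be read, because each of those two compounds stands at a limit: the limit of > 50000 nM in this assay, at which 2 of the 4 values shown sit. Among the compounds shown here, the only step with actual numbers at both ends shows that the other end of the molecule also counts, with 3,4-dimethoxyphenyl in place of 3,4-dihydroxyphenyl giving a 2.2-fold higher number from compound 2 to compound 4 (0.34 log units; beyond the scatter).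

The step to compound 4 exchanges sulfur for oxygen and chlorine for fluorine together, and the compounds shown do not separate the two changes. Also open, as far as these compounds go, is how an amine or a carboxylic acid on the aromatic ring of the 4-fluorophenyl group, or a longer chain on the oxygens of the 3,4-dimethoxyphenyl group, would read here.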